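Chloromethyl on the chain of compound 2

This account rests on a few compounds, and the source may have more. Where it says the series, first, only, none or still open, it means among the compounds named here.

Within the data shown here, in an in vivo ADME assay on the whole organism for metabolic stability, with Rattus norvegicus as the target, at a dose of 3 mg/kg by the oral route (a higher number here means that the compound lasts longer, a lower number that the compound disappears faster), compound 2 `COCCOCCOc1ccc(-c2nc(-c3ccnc(C)c3)n[nH]2)cc1C#N` gives 0.97 h, the higher of the two numbers so far, and compound 1 `COCCOCOc1ccc(-c2nc(-c3ccnc(C)c3)n[nH]2)cc1C#N` gives 0.45 h. Among the measured compounds shown here, the only measured step, a 2.2-fold higher number from compound 1 to compound 2 (0.33 log units; beyond the scatter), is modest but beyond the scatter, and it lies in the same chain. Compound 3 `Cc1cc(-c2n[nH]c(-c3ccc(OCCOCCOCCCl)c(C#N)c3)n2)ccn1` differs from compound 2 by one change: chloromethyl in place of hydrogen on a saturated chain carbon bound to an oxygen on a saturated carbon. That single step gives no direction for this change, so no shift beyond the scatter is expected in this assay. The expected step is a 1.1-fold lower number from compound 2 to compound 3 (0.03 log units; within the scatter). For compound 3 the estimated half-life is 0.9 h, with an expected range from 0.45 h to 1.8 h.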

Compound 3, half-life: 0.52 h
Beside the measured number, compound 3's estimate is 1.7-fold (0.24 log units) above it, and the stated range covers the measured number.
By their numbers in this assay, from the lowest: compounds 1, 3 and 2 (each within the scatter of the next, the first and the last beyond it).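

In this assay, chloromethyl in place of hydrogen on a saturated chain carbon bound to an oxygen on a saturated carbon gives a 1.9-fold lower number from compound 2 to compound 3 (0.27 log units; within the scatter) and so does not separate compound 3 from compound 2. Measured against the shorter chain, (2-(2-chloroethoxy)ethoxy)methyl in place of 2-methoxyethoxy gives a 1.2-fold higher number from compound 1 to compound 3 (0.06 log units; within the scatter) and does not separate compound 3 from compound 1 either. Nothing measured here explains either step. Still open, as far as these compounds go, is whether an amine or a carboxylic acid at this chain carbon would give a step beyond the scatter. From the compounds shown here alone, a longer chain without chlorine also remains open.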